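This account rests on a few compounds, and the source may have more. Where it says the series, first, only, none or still open, it means among the compounds named here.

Measured so far in an ADME assay on H9 cells (Homo sapiens) for cytotoxicity, read by XTT assay, with a stated time of 6 days; on this read-out lower numbers stand for higher toxicity in this test and higher numbers for lower toxicity in this test:
compound 1 `COc1ccc(Nc2cc(Oc3c(C)cc(Br)cc3C)c([N+](=O)[O-])cc2[N+](=O)[O-])cc1`: 51200 nM
compound 2 `COc1ccc(Nc2cc(Oc3c(C)cc(C)cc3C)c([N+](=O)[O-])cc2[N+](=O)[O-])cc1`: > 59100 nM (a limit)
compound 3 `Cc1cc(Br)cc(C)c1Oc1ccc([N+](=O)[O-])c(Nc2ccc(C#N)cc2)c1`: > 57000 nM (a limit)

Compound 2 has no exact number, and it stands at the limit of > 59100 nM in this assay, at which 1 of the 3 values shown sits. Compound 3 also has only a limit, and it stands at the limit of > 57000 nM in this assay, at which 1 of the 3 values shown sits.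

The next compound is compound 4 `COc1ccc(Nc2cc(Oc3c(C)cccc3C)c([N+](=O)[O-])cc2[N+](=O)[O-])cc1`. Here hydrogen takes the place of methyl on an aromatic carbon, para to a large group, so that 2,4,6-trimethylphenoxy becomes 2,6-dimethylphenoxy: hydrogen in place of methyl on an aromatic carbon.

Among the measured compounds shown here, one measured step bears on this change, because it alters the group at that same carbon: an at least 1.1-fold higher number from compound 1 to compound 2 (0.06 log units; that floor lies within the scatter). That step swaps bromo for methyl and shows no change beyond the scatter, though it is only a floor. No step beyond the scatter is therefore expected in this assay, in either direction, and a further limit is quite possible. The expected step is a step that the limit leaves unreadable from compound 2 to compound 4. For compound 4 the estimated value is 60000 nM, with an expected range of 25000 nM to 90000 nM.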

Compound 4, half-maximal cytotoxic concentration: > 61100 nM
Compound 4 ended at the assay's limit (the forecaster's own chance of this, stated with the estimate: 65%); middle value at least 1.0-fold (0.00 log units) from the limit.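

In this assay, compound 4 gives only a limit, > 61100 nM. Compound 2 and compound 4 both carry limits, so the step between them cannot be read, and nothing can be said about hydrogen against methyl at this carbon. Against bromo, the comparison gives an at least 1.1-fold higher number from compound 1 to compound 4 (0.07 log units; that floor lies within the scatter), so with hydrogen, as with methyl, no step beyond the scatter has appeared at this position, although a floor cannot rule one out.

Going by these compounds, the exact values of compound 2 and compound 4 remain unknown, so any real difference between them stays hidden. On these data alone, whether a different kind of group on this carbon, such as an amine or a carboxylic acid, would bring a clear step in either direction also remains open.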